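The source may hold more compounds than are shown below. What is called first, only, known or untested is meant among the compounds shown, and "the series" means these compounds.

Working notes on the series. Every member shares one core and differs only in the amide substituent on the carbonyl carbon. Compound 1 `Cc1ccc(CN(C)C(=O)c2nn(-c3ccc(F)cc3)c(OC[C@@H](O)C[C@@H](O)CC(=O)O)c2C(C)C)cc1` gives 37 nM in an assay on microsomes from liver for inhibition of 3-hydroxy-3-methylglutaryl-coenzyme A reductase (Rattus norvegicus); on this read-out higher numbers stand for weaker inhibition and lower numbers for stronger inhibition. Compound 2 `CC(C)c1c(C(=O)N2CCCC2c2ccccc2)nn(-c2ccc(F)cc2)c1OC[C@@H](O)C[C@@H](O)CC(=O)O` gives 14 nM in this assay, and compound 3 `CC(C)c1c(C(=O)NCc2ccccn2)nn(-c2ccc(F)cc2)c1OC[C@@H](O)C[C@@H](O)CC(=O)O` gives 25 nM in this assay. Compound 3 sits within the scatter of both others: a 1.5-fold lower number from compound 1 to compound 3 (0.17 log units; within the scatter) and a 1.8-fold higher number from compound 2 to compound 3 (0.25 log units; within the scatter), while only a 2.6-fold lower number from compound 1 to compound 2 (0.42 log units; beyond the scatter) passes beyond it. Compound 4 `CC(C)c1c(C(=O)NCc2ccc(Cl)cc2)nn(-c2ccc(F)cc2)c1OC[C@@H](O)C[C@@H](O)CC(=O)O` differs from compound 3 by 4-chlorophenyl in place of pyridin-2-yl on a saturated chain carbon bound to an amide-type nitrogen. All three measured steps exchange the amide substituent, none repeats this exchange, and their sizes are modest at most. The expected step is therefore no change at the digits printed from compound 3 to compound 4 (within the scatter), with no direction beyond the scatter. Compound 4 is expected to give 25 nM in this assay, estimated between 10 nM and 60 nM.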

Compound 4, half-maximal inhibitory concentration: 6.7 nM
Estimate against measurement, compound 4: 3.7-fold (0.57 log units) above; measured number below the stated range.
By their numbers in this assay, from the lowest: compound 4; then compounds 2, 3 and 1 (each within the scatter of the next, the first and the last beyond it).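

The place on a saturated chain carbon bound to an amide-type nitrogen responds to the ring it carries in this assay with a 3.7-fold lower number from compound 3 to compound 4 (0.57 log units; beyond the scatter) as 4-chlorophenyl replaces pyridin-2-yl. The other two amides also fall short, with a 2.1-fold lower number from compound 2 to compound 4 (0.32 log units; beyond the scatter) and a 5.5-fold lower number from compound 1 to compound 4 (0.74 log units; beyond the scatter) as steps, which makes compound 4 the strongest inhibitor of the four. Nothing measured here accounts for these steps. The exchange alters the ring atoms and adds chlorine together, so the compounds shown leave open what benzyl or 4-methoxybenzyl would give at this place.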